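Trifluoromethoxy for Chloro at the Aryl Ether Position

This account rests on a few compounds, and the source may have more. Where it says the series, first, only, none or still open, it means among the compounds named here.

Of the compounds shown here, two from this series have been measured in an assay on isolated protein for inhibition of AP2-associated protein kinase 1 (Homo sapiens), with a stated time of 3 h, in the presence of a further agent that is not named here; on this read-out higher numbers stand for weaker inhibition and lower numbers for stronger inhibition. Compound 1 `CC(=O)Nc1cc(-c2ccc(OC[C@@H](N)CC(C)C)c(C)c2)ccn1` gives 0.4 nM in this assay. Compound 2 `CC(=O)Nc1cc(-c2ccc(OC[C@@H](N)CC(C)C)c(Cl)c2)ccn1` gives 0.5 nM in this assay. Among the measured compounds shown here, the one step between them, a 1.3-fold higher number from compound 1 to compound 2 (0.10 log units; within the scatter), leaves the two compounds indistinguishable within the scatter. Compound 2 thus stands at the highest of the two numbers, with compound 1 as its nearest neighbour, and the pair sits together within the scatter.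

Compound 3 `CC(=O)Nc1cc(-c2ccc(OC[C@@H](N)CC(C)C)c(OC(F)(F)F)c2)ccn1` has not yet been measured in this assay. It differs from compound 2 in a single place: trifluoromethoxy in place of chloro on an aromatic carbon. For the measured compounds named here, the only measured step that bears on this change is the one from compound 1 to compound 2, which also exchanged the group at this very position and moved the number only within the scatter. On that basis, the exchange in compound 3 is expected to produce at most a modest shift in this assay, if any, most plausibly toward a somewhat higher number; the expected step is a 1.6-fold higher number from compound 2 to compound 3 (0.20 log units; within the scatter). Compound 3 is therefore estimated to give 0.8 nM in this assay, within a range from 0.3 nM to 2.5 nM.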

Compound 3, half-maximal inhibitory concentration: 0.5 nM
Estimate against measurement, compound 3: 1.6-fold (0.20 log units) above; the range from low to high includes it.
By their numbers in this assay, from the lowest: compounds 1, 2 and 3 (each within the scatter of the next).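

In this assay the position on the aromatic carbon ortho to the (2-amino-4-methylpentyl)oxy group now accommodates more than the swap between two single-atom-sized substituents seen earlier. Trifluoromethoxy, with 5 heavy atoms and 1 hydrogen-bond acceptor, replaces chloro, with 1 heavy atom and no hydrogen-bond acceptor, and the read-out shows no change at the digits printed from compound 2 to compound 3 (within the scatter), while the comparison with the methyl compound gives a 1.3-fold higher number from compound 1 to compound 3 (0.10 log units; within the scatter), so methyl, chloro and trifluoromethoxy all lie within the scatter of one another at this position. Nothing among the data shown explains why this exchange leaves the number in place.

What remains open is how far this tolerance extends, since an amine, a carboxylic acid or a longer chain such as butoxy at the same position would test groups of a different kind from the three shown here. Going by these compounds, it is also open whether trifluoromethoxy would read the same on a core that carries another chain in place of the (2-amino-4-methylpentyl)oxy group.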